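Working notes on compound 4: chain hydroxy to hydrogen

This account rests on a few compounds, and the source may have more. Where it says the series, first, only, none or still open, it means among the compounds named here.

Among the measured compounds shown here, compound 2 `COC1=C(OC)[C@H](O)[C@H](C/C=C(\C)CC/C=C(\C)C[C@H](O)/C=C(\C)CO)[C@@H](C)C1=O` is the one member of the series that returns a number in a functional assay on A549 cells (Homo sapiens) for inhibition, read by sulforhodamine B assay, with a stated time of 48 h (a lower number here means a stronger inhibitor of growth, a higher number a weaker inhibitor of growth), giving 12000 nM. Compound 1 `COC1=CC(=O)C(C/C=C(\C)CC/C=C(\C)CCC=C(C)C)=C(C)C1=O` sits at a limit of this assay, > 30000 nM. Compound 3 `COC1=C[C@H](O)[C@H](C/C=C(\C)CC/C=C(\C)C[C@H](O)/C=C(\C)CO)[C@@H](C)C1=O` likewise gives only a limit, > 30000 nM. For the measured compounds named here, the single change measured so far, an at least 2.5-fold higher number from compound 2 to compound 3 (0.39 log units; beyond the scatter), concerns the ring and not the chain, and its size is known only as a bound because of the limit of > 30000 nM in this assay, at which 2 of the 3 values shown sit. Compound 4 `COC1=C(OC)[C@H](O)[C@H](C/C=C(\C)CC/C=C(\C)C[C@H](O)C=C(C)C)[C@@H](C)C1=O` differs from compound 2 by hydrogen in place of hydroxy on a saturated chain carbon bound to a double-bonded chain carbon. Going by the values given here, no measured step touches this position, so no shift beyond the scatter can be argued from the series, and the expected step is small. Compound 4 is therefore estimated near 18000 nM, between 7000 nM and 40000 nM, which means an expected 1.5-fold higher number from compound 2 to compound 4 (0.18 log units; within the scatter).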

Compound 4, concentration for 50% growth inhibition: 9600 nM
The estimate for compound 4 lay 1.9-fold (0.27 log units) above the measured number; the range from low to high includes it.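

Among the compounds shown here, the first measured change on the chain rather than the ring, hydrogen in place of hydroxy on a saturated chain carbon bound to a double-bonded chain carbon, gives in this assay a 1.3-fold lower number from compound 2 to compound 4 (0.10 log units; within the scatter). Unlike the ring step, this one has a number at both ends, so its size is known and not merely bounded. This hydroxy can therefore go without a shift beyond the scatter.

Open, from the compounds shown here alone, is whether an amine or a carboxylic acid on this carbon would move the number beyond the scatter. Also open is how this change would read with the ring of compound 3, and steps to compounds at a limit give no exact size: the limit of > 30000 nM in this assay, at which 2 of the 4 values shown sit.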